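The source may report more compounds than this note shows. Statements on the series, on what has been measured and on what is new or still open speak of the compounds shown alone.

Measured compounds:
compound 1 `COc1cc(-c2cc(/C=C/C(=O)c3ccc(N)cc3)[nH]n2)cc(OC)c1OC` — 105%
compound 2 `COc1ccc(-c2cc(/C=C/C(=O)c3cc(OC)c(OC)c(OC)c3)[nH]n2)cc1OC` — 95%
compound 3 `COc1ccc(C(=O)/C=C/c2cc(-c3cc(OC)c(OC)c(OC)c3)n[nH]2)cc1` — 92%

In a functional assay on NCI-H23 cells (Homo sapiens) for cytotoxicity, read by sulforhodamine B assay, with a stated time of 48 h, tested at 0.1 uM (on this read-out lower numbers stand for a stronger effect and higher numbers for a weaker effect at the one concentration tested), compound 1 gives 105%, the highest of the three numbers. Compound 2 with 95% stands within the scatter of compound 1, while compound 3 with 92% lies beyond it. All three numbers sit close to no effect at the one concentration tested.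

Compound 4 `COc1ccc(C(=O)/C=C/c2cc(-c3cc(OC)c(OC)c(OC)c3)n[nH]2)cc1OC` is the next member. It differs from compound 1 by 3,4-dimethoxyphenyl in place of 4-aminophenyl on a carbonyl carbon. Among the compounds with values here, one measured step bears on this change: a number 13 percentage points lower from compound 1 to compound 3 (beyond the scatter), where the amino on the aromatic carbon was replaced by a methoxy. Compound 4 carries the same replacement together with a second methoxy on the entering ring. Compound 2 also holds a 3,4-dimethoxyphenyl, though on the shared core rather than on the carbonyl carbon, and its value lies within the scatter of compound 1. A modest downward step is therefore expected in this assay, of the order seen for compound 3, and not a larger one; the estimated step is a number 12 percentage points lower from compound 1 to compound 4 (beyond the scatter). Compound 4 is expected to give 93%, in the range 80% to 106%.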

Compound 4, a percentage reported as activity, at one concentration (the size of the read-out at that concentration, not a potency): 94%
For compound 4 the middle estimate is 1 percentage points below the measured one; measured number inside the range.
By their numbers in this assay, from the lowest: compounds 3, 4, 2 and 1 (each within the scatter of the next, the first and the last beyond it).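

In this assay, 3,4-dimethoxyphenyl in place of 4-aminophenyl on the carbonyl carbon gives a number 11 percentage points lower from compound 1 to compound 4 (beyond the scatter), so the downward step is also seen with this larger group. The added methoxy on an aromatic carbon gives a number 2 percentage points higher from compound 3 to compound 4 (within the scatter), so the second methoxy does not separate these two compounds at the one concentration tested. No measured evidence at hand accounts for the behaviour of this position.

On these data alone, whether a hydroxyl, a carboxylic acid or a dimethylamino group on the ring at the carbonyl carbon would move the number further remains open. Also open, as far as these compounds go, is whether these small steps would hold at a higher concentration, since a single-concentration read-out gives no potency.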